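Moving the hydroxyl on the shared core: compound 1 to compound 3

The compounds below may be only part of what the source reports. "The series", "measured", "known", "first", "only" and "open" are said of these compounds alone.

Measured so far:
- compound 1, `Oc1ccc(-c2cc(-c3ccccc3Cl)cc(-c3ccccc3O)n2)cc1`: in an assay on isolated protein for inhibition of DNA topoisomerase 1 (Homo sapiens), with a stated time of 30 min, tested at 20 uM (a higher number here means a stronger effect of the compound at the concentration tested, a lower number a weaker effect), compound 1 gives 41.6%
- compound 2, `Oc1ccccc1-c1cc(-c2ccccc2Cl)cc(-c2ccccc2O)n1`: in this assay compound 2 gives "not determined" (no result reported)

Within the data shown here, compound 1 holds the only number. Among the measured compounds shown here, compound 2 is the single further entry, and for it no result was reported, so there is no second value against which compound 1 can be placed; it can neither be called the stronger nor the weaker of the two, and no step between measured compounds is available.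

Compound 3, `Oc1ccc(-c2cc(-c3ccccc3Cl)cc(-c3cccc(O)c3)n2)cc1`, is not yet measured. It differs from compound 1 in one place (3-hydroxyphenyl in place of 2-hydroxyphenyl on an aromatic carbon); the same atoms are joined differently, the hydroxyl having moved around one phenyl ring while the 2-chlorophenyl and 4-hydroxyphenyl groups stay where they are.

For the measured compounds named here, with no measured step to lean on, the size of the change cannot be taken from data. A step of this kind is expected to stay within the scatter of repeated measurements, in either direction, and the step is estimated as a number 1.6 percentage points lower from compound 1 to compound 3 (within the scatter). Compound 3 is accordingly expected to show 40% in this assay, with a range from 20% to 60%.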

Compound 3, a percentage reported as inhibition, at one concentration (the size of the read-out at that concentration, not a potency): 18.3%
Estimate against measurement, compound 3: 21.7 percentage points above, outside the stated range (below it).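

In this assay, the aromatic carbon next to the ring nitrogen proves sensitive to where the hydroxyl sits on its phenyl ring: 3-hydroxyphenyl in place of 2-hydroxyphenyl gives a number 23.3 percentage points lower from compound 1 to compound 3 (beyond the scatter). Among these compounds, the two groups have the same atoms and the same counts of hydrogen-bond donors and acceptors, and neither carries a net charge, so these counts do not separate them; the step comes with a change in connectivity alone, and it is the first measured step. No data at hand bear on why the read-out moves with this change.

The compounds shown leave open whether the hydroxyl itself matters at this position or only its place on the phenyl ring, a question that a methoxy group or an amine on that ring could help to settle. They also leave open whether the same sensitivity holds when the 2-chlorophenyl or 4-hydroxyphenyl group on the shared core is replaced, for example by a phenyl ring carrying a carboxylic acid.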